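The compounds below may be only part of what the source reports. "The series", "measured", "known", "first", "only" and "open" are said of these compounds alone.

In a functional assay on MCF7 cells (Homo sapiens) for antiproliferative activity, read by MTT assay, with stated times of 24 h and 72 h (on this read-out lower numbers stand for stronger inhibition and higher numbers for weaker inhibition), compound 1 `COc1ccc([C@@H]2[C@@H](Oc3ccccc3)C(=O)N2c2cc(OC)c(OC)c(OC)c2)cc1` gives 6900 nM, and compound 3 `COc1cc(N2C(=O)[C@H](Oc3ccccc3)[C@H]2c2ccc(C#N)cc2)cc(OC)c1OC` gives 168000 nM. Compound 2 `COc1cc(N2C(=O)[C@@H](Oc3ccccc3)[C@H]2c2ccc(Br)cc2)cc(OC)c1OC` gives 48000 nM, which places it between the other two, with both gaps beyond the scatter. Compound 4 `COc1cc(N2C(=O)[C@@H](Oc3ccccc3)[C@H]2c2cccc3ccccc23)cc(OC)c1OC` carries naphthalen-1-yl in place of 4-bromophenyl on a saturated ring carbon. Among the compounds with values here, only one measured step bears on this change, namely a 24-fold higher number from compound 1 to compound 3 (1.39 log units; beyond the scatter), a large step with cyano in place of methoxy on an aromatic carbon. It shows that a change within this aromatic group can shift this assay strongly, but it involves neither the 4-bromophenyl nor the naphthalen-1-yl group. The data therefore give no direction for the new change, and no step beyond the scatter is expected, though the uncertainty is wide. The expected step is a 1.2-fold lower number from compound 2 to compound 4 (0.08 log units; within the scatter). For compound 4 the estimated value is 40000 nM, with an expected range of 10000 nM to 150000 nM.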

Compound 4, half-maximal inhibitory concentration: 53000 nM
Beside the measured number, compound 4's estimate is 1.3-fold (0.12 log units) below it, and the stated range covers the measured number.
By their numbers in this assay, from the lowest: compound 1; then compounds 2 and 4 (each within the scatter of the next); then compound 3.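

In this assay, naphthalen-1-yl in place of 4-bromophenyl on a saturated ring carbon gives a 1.1-fold higher number from compound 2 to compound 4 (0.04 log units; within the scatter), the first step shown that reads this position directly. At this position, the two groups cannot be told apart in this read-out, even though naphthalen-1-yl has 10 heavy atoms and 2 six-membered aromatic rings, while 4-bromophenyl has 7 heavy atoms and one such ring. No measured property of either group is available to account for this result.

The compounds shown leave open whether a pyridine ring, a cyclohexyl group or a phenyl ring bearing an amine would also read alike at this position. They also leave open whether the two groups would still read alike with a hydroxy group in place of the phenoxy group that both compounds carry.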